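The compounds below may be only part of what the source reports. "The series", "measured", "known", "first", "only" and "open" are said of these compounds alone.

Measured so far in a functional assay on Huh-7 cells (Homo sapiens) for cytotoxicity, with a stated time of 48 h; a lower number here means a stronger inhibitor, a higher number a weaker inhibitor:
- compound 1 `O=[N+]([O-])c1ccc(CN2CCC(n3cc(CC(OCc4cc(-c5ccccc5)no4)c4ccc(Br)cc4)nn3)CC2)cc1`: 7000 nM
- compound 2 `O=[N+]([O-])c1ccc(CN2CCC(n3cc(CC(OCc4cc(-c5ccc(F)cc5)no4)c4ccc(Br)cc4)nn3)CC2)cc1`: 2000 nM
- compound 3 `O=[N+]([O-])c1ccc(CN2CCC(n3cc(CC(OCc4cc(-c5cccc(Br)c5)no4)c4ccc(Br)cc4)nn3)CC2)cc1`: 3000 nM

Compound 3 holds the second highest of the three numbers. Its nearest neighbour is compound 2, and the step of a 1.5-fold higher number from compound 2 to compound 3 (0.18 log units; within the scatter) stays within the scatter; the furthest is compound 1, and the step of a 2.3-fold lower number from compound 1 to compound 3 (0.37 log units; beyond the scatter) lies beyond it.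

Compound 4 `O=[N+]([O-])c1ccc(CN2CCC(n3cc(CC(OCc4cc(-c5ccccc5F)no4)c4ccc(Br)cc4)nn3)CC2)cc1` differs from compound 3 in one place: 2-fluorophenyl in place of 3-bromophenyl on an aromatic carbon. Within the data shown here, two measured steps bear on a halogen on this phenyl: a 3.5-fold lower number from compound 1 to compound 2 (0.54 log units; beyond the scatter) and a 2.3-fold lower number from compound 1 to compound 3 (0.37 log units; beyond the scatter), both modest and both lowering the number relative to the unsubstituted phenyl of compound 1. Between the two halogenated analogues, a 1.5-fold higher number from compound 2 to compound 3 (0.18 log units; within the scatter) shows no separation. Compound 4 keeps a halogen on the phenyl but moves it to a position not yet covered by any measured step, so the series gives no ground for a shift beyond the scatter in this assay. The expected step is a 1.2-fold lower number from compound 3 to compound 4 (0.08 log units; within the scatter), within the scatter. Compound 4 is thus estimated at 2500 nM, with a range from 1000 nM to 7000 nM.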

Compound 4, half-maximal inhibitory concentration: 2000 nM
Compound 4: middle estimate off by 1.3-fold (0.10 log units), on the high side; the range from low to high includes it.
By their numbers in this assay, from the lowest: compounds 2, 4 and 3 (each within the scatter of the next); then compound 1.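

In this assay the 2-fluorophenyl group becomes the third halogenated phenyl to sit beyond the scatter of the unsubstituted phenyl of compound 1 (a 3.5-fold lower number from compound 1 to compound 4 (0.54 log units; beyond the scatter)). Among the halogenated analogues the change does not register (no change at the digits printed from compound 2 to compound 4 (within the scatter); a 1.5-fold lower number from compound 3 to compound 4 (0.18 log units; within the scatter)), so neither the kind of halogen nor its place on this phenyl separates compound 2, compound 3 and compound 4 in these data. No measurement at hand explains this flat response.

Still open, going by these compounds, is whether the gain over compound 1 is tied to a halogen at all, or whether a methoxy group, an amine or a carboxylic acid on this phenyl would sit at the same level. Also open, on these data alone, is how a phenyl carrying two fluorines would compare with these single-halogen analogues.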